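The source may hold more compounds than are shown below. What is called first, only, known or untested is meant among the compounds shown, and "the series" means these compounds.

Measured so far:
- compound 1, `O=S(=O)(NCCCNCc1ccc(Cl)c(C(F)(F)F)c1)c1cc(C(F)(F)F)cc(C(F)(F)F)c1`: 10000 nM
- compound 2, `O=S(=O)(NCCCNCC1COc2ccccc2O1)c1cc(C(F)(F)F)cc(C(F)(F)F)c1`: 3400 nM

In a functional assay on PANC-1 cells (Homo sapiens) for inhibition, read by MTT assay, with a stated time of 72 h (a lower number here means a stronger inhibitor of growth, a higher number a weaker inhibitor of growth), compound 2 gives 3400 nM, the lowest of the two numbers; compound 1 sits a 2.9-fold lower number from compound 1 to compound 2 (0.47 log units; beyond the scatter). Among the measured compounds shown here, that single step is the only comparison available, and it shows that exchanging 4-chloro-3-(trifluoromethyl)phenyl for 2,3-dihydro-1,4-benzodioxin-2-yl on the saturated chain carbon bound to the amine nitrogen lowered the number by a modest, scatter-exceeding amount.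

Compound 3, `O=S(=O)(NCCCNCc1ccc(C(F)(F)F)cc1)c1cc(C(F)(F)F)cc(C(F)(F)F)c1`, is not yet measured in this assay. Its difference from compound 2 is 4-(trifluoromethyl)phenyl in place of 2,3-dihydro-1,4-benzodioxin-2-yl on a saturated chain carbon bound to an amine nitrogen. For the measured compounds named here, this largely reverses the direction of the one known step, the entering group resembling that of compound 1 except that the chloro substituent is absent. The expectation is therefore a higher number, most of the way back toward compound 1, because a 2.9-fold lower number from compound 1 to compound 2 (0.47 log units; beyond the scatter) was modest; the estimated step is a 2.4-fold higher number from compound 2 to compound 3 (0.37 log units; beyond the scatter). Compound 3 is expected at about 8000 nM, within 3500 nM to 20000 nM.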

Compound 3, concentration for 50% growth inhibition: 3200 nM
Compound 3: middle estimate off by 2.5-fold (0.40 log units), on the high side; the whole stated range lies above it.
By their numbers in this assay, from the lowest: compounds 3 and 2 (each within the scatter of the next); then compound 1.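

In this assay, 4-(trifluoromethyl)phenyl in place of 2,3-dihydro-1,4-benzodioxin-2-yl on a saturated chain carbon bound to an amine nitrogen gives a 1.1-fold lower number from compound 2 to compound 3 (0.03 log units; within the scatter), so at this place a group with 0 hydrogen-bond acceptors and a group with 2 read alike. The same place, with 4-(trifluoromethyl)phenyl in place of 4-chloro-3-(trifluoromethyl)phenyl, gives a 3.1-fold lower number from compound 1 to compound 3 (0.49 log units; beyond the scatter), so the higher number of compound 1 goes with that particular substituted phenyl and not with a phenyl group at this place as such. No supporting data are available to explain either step.

Which part of 4-chloro-3-(trifluoromethyl)phenyl goes with the higher number stays open; 4-chlorophenyl and 3-(trifluoromethyl)phenyl at this place would separate the two substituents. On these data alone, how an unsubstituted phenyl or a longer chain would read in this assay is also open.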